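The compounds below may be only part of what the source reports. "The series", "measured", "known", "first", "only" and "open" are said of these compounds alone.

Measured so far:
Compound 1, `COc1ccc(-c2[nH]c3ccccc3c2/C=C(\C#N)S(=O)(=O)c2ccccc2)cc1`, in a functional assay on DU-145 cells (Homo sapiens) for inhibition, read by sulforhodamine B assay, with a stated time of 48 h (on this read-out lower numbers stand for stronger inhibition of growth and higher numbers for weaker inhibition of growth), compound 1 gives 450 nM.
Compound 2, `COc1ccc(-c2[nH]c3ccc(OC)cc3c2/C=C(\C#N)S(=O)(=O)c2ccccc2)cc1`, in this assay compound 2 gives 875 nM.

Compound 2 carries the higher of the two numbers, and its nearest neighbour is compound 1: the step from compound 1 to compound 2 is a 1.9-fold higher number from compound 1 to compound 2 (0.29 log units; within the scatter), so the two stand together rather than apart. That step adds a methoxy group to one ring of the shared core.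

Compound 3, `COc1ccc2[nH]c(-c3ccccc3)c(/C=C(\C#N)S(=O)(=O)c3ccccc3)c2c1`, has not yet been measured. It differs from compound 2 by hydrogen in place of methoxy on an aromatic carbon; cut one bond further out, the difference reads 4-methoxyphenyl to phenyl. Within the data shown here, only one measured step exists, from compound 1 to compound 2, and it concerns a methoxy group on a different ring, so it bears on the new change only loosely. That step stayed within the scatter, and the same is expected here: compound 3 is expected to land near compound 2, with the step from compound 2 to compound 3 estimated as a 1.3-fold lower number from compound 2 to compound 3 (0.10 log units; within the scatter). The estimate for compound 3 is 700 nM, within a range from 300 nM to 1600 nM.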

Compound 3, concentration for 50% growth inhibition: 10100 nM
Compound 3: middle estimate off by 14-fold (1.16 log units), on the low side, outside the stated range (above it).
By their numbers in this assay, from the lowest: compounds 1 and 2 (each within the scatter of the next); then compound 3.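

In this assay, among these compounds, replacing 4-methoxyphenyl with phenyl gives a 12-fold higher number from compound 2 to compound 3 (1.06 log units; beyond the scatter), a large loss of growth inhibition and the first step to lie beyond the scatter. Among the compounds shown here, the only earlier step, a 1.9-fold higher number from compound 1 to compound 2 (0.29 log units; within the scatter), added a methoxy group on a different ring and left the two compounds together, so the numbers do not respond equally to a methoxy group at these two places: here, on a six-membered aromatic ring of carbon only and para to a large group, its removal matters far more. Nothing measured here accounts for the size of this step.

From the compounds shown here alone, with only methoxy and hydrogen compared at this place, it remains open whether the whole methoxy group is needed or whether a hydroxyl group, an ethoxy group, a fluorine atom or an amine could take its place and keep the number low. Going by these compounds, it is also open whether the same large step would appear on the core of compound 1, which lacks the methoxy group on the other ring.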